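The compounds below may be only part of what the source reports. "The series", "measured", "known", "first", "only" and "open" are said of these compounds alone.

Compound 1 `C=C(Br)C(=O)Nc1cccc(-c2cn3nc(-c4ccccc4)sc3n2)c1` gives the lowest of the three numbers measured in a functional assay on FM3A cells (Mus musculus) for inhibition, read by cell counting, with a stated time of 2 days; a higher number here means a weaker inhibitor, a lower number a stronger inhibitor: compound 1 gives 900 nM. Compound 3 `Nc1cccc(-c2cn3nc(-c4ccccc4)sc3n2)c1`, in this assay, gives 14000 nM, and compound 2 `Nc1cccc(-c2cn3nc(CCc4ccccc4)sc3n2)c1` gives 29000 nM. Among the compounds with values here, the one step measured in one place, a 16-fold higher number from compound 1 to compound 3 (1.19 log units; beyond the scatter), concerns the amide and not the part changed here. Compound 4 `C=C(Br)C(=O)Nc1cccc(-c2cn3nc(Cc4ccc(OC)cc4)sc3n2)c1` differs from compound 1 by 4-methoxybenzyl in place of phenyl on an aromatic carbon. Within the data shown here, no measured step bears directly on this change; compound 2 and compound 3 only show what two groups at the same place give when the amine is free. The expected step in this assay, a 1.7-fold higher number from compound 1 to compound 4 (0.22 log units; within the scatter), is therefore modest. Compound 4 is expected to give about 1500 nM, between 400 nM and 6000 nM.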

Compound 4, half-maximal inhibitory concentration: 850 nM
The estimate for compound 4 lay 1.8-fold (0.25 log units) above the measured number; the measured number falls inside the stated range.
By their numbers in this assay, from the lowest: compounds 4 and 1 (each within the scatter of the next); then compound 3; then compound 2.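

In this assay the change from phenyl to 4-methoxybenzyl on the aromatic carbon gives a step within the scatter (a 1.1-fold lower number from compound 1 to compound 4 (0.02 log units; within the scatter)), so compound 1 and compound 4 read alike with the (1-bromoethenyl)carbonyl amide present. The earlier compounds had shown this place only with the free amine, and this pair shows that a group with more heavy atoms and a hydrogen-bond acceptor can stand there with no step beyond the scatter. No evidence is available to explain this result. As far as these compounds go, whether an amine, a carboxylic acid or a longer chain at this place would also read alike remains open.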